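The source may report more compounds than this note shows. Statements on the series, on what has been measured and on what is new or still open speak of the compounds shown alone.

Compound 1 `Fc1cccc(-c2nc(Nc3ccccc3)c3ccccc3n2)c1`: in a functional assay on HT29-AK cells (Homo sapiens) for cytotoxicity, read by MTT assay, with a stated time of 48 h (on this read-out higher numbers stand for weaker inhibition and lower numbers for stronger inhibition), compound 1 gives > 50000 nM, which is a limit of the assay and not a number.
Compound 2 `Fc1ccc2nc(-c3ccccc3)nc(Nc3ccccc3)c2c1`: in this assay compound 2 gives > 50000 nM, likewise a limit rather than a number.
Compound 3 `Fc1cccc(-c2nc(Nc3ccc(Br)cc3)c3cc(F)ccc3n2)c1`: in this assay compound 3 gives > 50000 nM, again a limit and not a number.

The three measured compounds share the core seen in compound 1 and differ only in fluoro and bromo substitution on their outer rings. None of them yields a number in this assay: the limit of > 50000 nM in this assay, at which 3 of the 3 values shown sit. Among the measured compounds shown here, compound 3 therefore stands at the limit together with the other two, with nothing in the numbers to set it apart, and no step between measured compounds can be drawn from such data.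

Compound 4 `Cc1ccc(Nc2nc(-c3cccc(F)c3)nc3ccc(F)cc23)cc1` differs from compound 3 in one place: methyl in place of bromo on an aromatic carbon. Every measured value sits at the limit. For the measured compounds named here, there is thus no measured step from which the effect of this change could be read. The step expected in this assay is a step that the limit leaves unreadable from compound 3 to compound 4, that is, none beyond the usual scatter. Compound 4 is accordingly estimated at 80000 nM, with a range from 20000 nM to 300000 nM, and the assay is expected most likely to report only its limit once more.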

Compound 4, half-maximal inhibitory concentration: > 50000 nM
Compound 4: no number, only a limit (the forecaster's own chance of this, stated with the estimate: 85%); the middle value is on the limit's open side.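

Among the compounds shown here, compound 3 and compound 4 both give only a limit in this assay, so no step between them can be read and the exchange of bromo for methyl cannot be sized: the limit of > 50000 nM in this assay, at which 4 of the 4 values shown sit. The compounds shown leave open whether any change to the shared core would give a measurable value in this assay.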